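This account rests on a few compounds, and the source may have more. Where it says the series, first, only, none or still open, it means among the compounds named here.

Measured compounds in an assay on isolated protein with Bile acid receptor (Homo sapiens) as the target; on this read-out higher numbers stand for an effect only at larger amounts of compound and lower numbers for an effect already at smaller amounts:
- compound 1 `COC(=O)/C=C/c1cccc(N(Cc2ccc(/C=C/C(=O)O)cc2)C(=O)C2CCCCC2)c1` gives 1000 nM
- compound 2 `COC(=O)/C=C/c1cccc(N(Cc2ccc(/C=C/c3cccc(Cl)c3)cc2)C(=O)C(C)C)c1` gives 162 nM
- compound 3 `COC(=O)/C=C/c1cccc(N(Cc2ccc(/C=C/c3ccccc3)cc2)C(=O)C(C)C)c1` gives 64.6 nM

Compound 3 stands at the lowest number of the three, with compound 2 the nearest and compound 1 the furthest from it. Among the measured compounds shown here, the step of a 2.5-fold lower number from compound 2 to compound 3 (0.40 log units; beyond the scatter) is the only single-site change among the measured compounds. Compound 4 `COC(=O)/C=C/c1cccc(N(Cc2ccc(-c3cccc(OC)c3)cc2)C(=O)C(C)C)c1` is not yet measured; it differs from compound 3 by 3-methoxyphenyl in place of 2-phenylethenyl on an aromatic carbon. For the measured compounds named here, no measured step touches this kind of exchange, so the expectation rests only on the spread of this assay across compounds 1 to 3. A modest rise in the number is expected, as the step of a 2.3-fold higher number from compound 3 to compound 4 (0.37 log units; beyond the scatter). Compound 4 is expected at 150 nM, with a range from 50 nM to 500 nM.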

Compound 4, half-maximal effective concentration: 72.4 nM
The estimate for compound 4 lay 2.1-fold (0.32 log units) above the measured number, and the stated range covers the measured number.
By their numbers in this assay, from the lowest: compounds 3 and 4 (each within the scatter of the next); then compound 2; then compound 1.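

In this assay, a directly attached 3-methoxyphenyl can stand in for 2-phenylethenyl on this aromatic carbon with no change beyond the scatter (a 1.1-fold higher number from compound 3 to compound 4 (0.05 log units; within the scatter)), so the ethenyl link is not required at this position. Against the chlorinated styryl-type group of compound 2, the same aryl group gives a lower number (a 2.2-fold lower number from compound 2 to compound 4 (0.35 log units; beyond the scatter)). No supporting data explain either step.

Going by these compounds, it remains open whether the methoxy group contributes at all, as plain phenyl would show. On these data alone, an amine or a carboxylic acid in its place also remains untested here.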